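This account rests on a few compounds, and the source may have more. Where it says the series, first, only, none or still open, it means among the compounds named here.

Of the compounds shown here, two of a shared core have been tested so far. Compound 2 `COc1cc(/C=C/C(=O)C2=C(/C=C/c3ccc(O)c(OC)c3)NC(=S)NC2c2ccc(N(C)C)cc2)ccc1O` and compound 1 `COc1cc(/C=C/C(=O)C2=C(/C=C/c3ccc(O)c(OC)c3)NC(=S)NC2c2ccccc2O)ccc1O` differ only in the group attached to a saturated ring carbon. In a functional assay, with a stated time of 20 min, tested at 2 uM (on this read-out higher numbers stand for a stronger effect at the one concentration tested and lower numbers for a weaker effect), compound 2 gives 30.2%, and in this assay compound 1 gives 25%. These two numbers cannot be told apart, because a number 5.2 percentage points higher from compound 1 to compound 2 (within the scatter) is a step within the scatter; compound 2 therefore stands on even ground with compound 1, not apart from it.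

Compound 3 `COc1cc(/C=C/C(=O)C2=C(/C=C/c3ccc(O)c(OC)c3)NC(=S)NC2c2ccccc2Cl)ccc1O` is the next compound in this series and has not yet been measured. It differs from compound 2 as follows: 2-chlorophenyl in place of 4-(dimethylamino)phenyl on a saturated ring carbon

Within the data shown here, the only measured step that bears on this position is the one from compound 1 to compound 2, and a number 5.2 percentage points higher from compound 1 to compound 2 (within the scatter) was within the scatter. Swapping one aryl group for another at this saturated ring carbon has so far not moved the number beyond the scatter, so the expectation for compound 3 is a step of similar size, a number 3.2 percentage points lower from compound 2 to compound 3 (within the scatter), which is no step beyond the scatter. Compound 3 is therefore estimated to give 27%, with a range from 12% to 42%.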

Compound 3, a percentage reported as activity, at one concentration (the size of the read-out at that concentration, not a potency): 16.2%
Compound 3: middle estimate off by 10.8 percentage points, on the high side; the range from low to high includes it.
By their numbers in this assay, from the lowest: compounds 3, 1 and 2 (each within the scatter of the next, the first and the last beyond it).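

In this assay, this saturated ring carbon now shows that an aryl swap can move the read-out beyond the scatter: 2-chlorophenyl in place of 4-(dimethylamino)phenyl gives a number 14 percentage points lower from compound 2 to compound 3 (beyond the scatter), a modest step. Chloro in place of hydroxy on the aromatic carbon gives only a number 8.8 percentage points lower from compound 1 to compound 3 (within the scatter), so compound 1 cannot be told apart from either of the other two compounds, and only the pair at the two ends of the series separates. Nothing measured here accounts for the drop at this position.

The separated pair differs both in the group carried on the phenyl ring and in where that group sits, and the compounds shown cannot pull these two changes apart; 4-chlorophenyl or 2-(dimethylamino)phenyl at the same carbon would be needed for that. Also open, as far as these compounds go, is how this carbon responds to a plain phenyl, to a phenyl bearing a carboxylic acid, or to a simple alkyl chain in place of any aryl group.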